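A few compounds are considered here, and "the series" means these few. Any claim that something is new, unique, unknown or untested is made for them only; others in the source may bear on it.

Two sulfonamides built on the same uracil-derived core have been measured. In a functional assay on SGC-7901 cells (Homo sapiens) for antiproliferative activity, read by MTT assay, with a stated time of 24 h (on this read-out lower numbers stand for stronger inhibition and higher numbers for weaker inhibition), compound 1 `O=c1[nH]cc(S(=O)(=O)Nc2cccc(-c3cn(-c4ccccc4)nn3)c2)c(=O)[nH]1` gives 17200 nM. Compound 2 `Cc1ccccc1-n1cc(-c2ccc(NS(=O)(=O)c3c[nH]c(=O)[nH]c3=O)cc2)nn1`, carrying the amide on the other ring position and a 2-methylphenyl on the triazole nitrogen, gives 13600 nM in this assay; the two numbers lie within the scatter of each other, so compound 2 and compound 1 read as equivalent here. Compound 3 `O=c1[nH]cc(S(=O)(=O)Nc2ccc(-c3cn(-c4ccc(Cl)cc4)nn3)cc2)c(=O)[nH]1` has not been measured in this assay. It differs from compound 2 by 4-chlorophenyl in place of 2-methylphenyl on an aromatic nitrogen. For the measured compounds named here, no measured pair shows what this exchange does, so the expectation rests only on the two numbers at hand, which place the whole series in the same narrow band. The step of a 1.2-fold lower number from compound 2 to compound 3 (0.09 log units; within the scatter) is expected to stay within the scatter, with no clear direction. Compound 3 is accordingly estimated at 11000 nM in this assay, with a plausible range from 4000 nM to 30000 nM.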

Compound 3, half-maximal inhibitory concentration: 1830 nM
Compound 3: the middle estimate sits 6.0-fold (0.78 log units) above what was measured, and the stated range ends above it.
By their numbers in this assay, from the lowest: compound 3; then compounds 2 and 1 (each within the scatter of the next).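

In this assay, for the compounds shown here, the exchange of 2-methylphenyl for 4-chlorophenyl on the aromatic nitrogen gives a 7.4-fold lower number from compound 2 to compound 3 (0.87 log units; beyond the scatter) and so shows that this position is not neutral, which the earlier compounds could not show. The two groups match in heavy-atom count and in their hydrogen-bond donor and acceptor counts, so those counts alone do not account for the step. No measured information on the compounds explains this difference.

The exchange alters both the substituent and its place on the phenyl ring, and the compounds shown do not separate these two changes. Going by these compounds, how 2-chlorophenyl and 4-methylphenyl would read stays open, as does whether a phenyl carrying an amine or a carboxylic acid at the same ring place would keep the lower number.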